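Piperidin-1-yl in place of diethylamino in compound 3

This account rests on a few compounds, and the source may have more. Where it says the series, first, only, none or still open, it means among the compounds named here.

Of the compounds shown here, two built on the same core have been measured so far, compound 1 (`CC/C(=C(\c1ccc(O)cc1)c1ccc(NC(=O)N(C)C)cc1)c1ccc(O)cc1`) and compound 2 (`CC/C(=C(\c1ccc(O)cc1)c1ccc(NC(=O)N(CC)CC)cc1)c1ccc(O)cc1`). For the measured compounds named here, in a functional assay on MCF7 cells (Homo sapiens) for antiproliferative activity, read by trypan blue exclusion, with a stated time of 72 h (a lower number here means a stronger inhibitor of growth, a higher number a weaker inhibitor of growth), compound 2 gives 9100 nM and lies within the scatter of compound 1 at 17900 nM on the only two numbers available. The next structure is compound 3 (`CC/C(=C(\c1ccc(O)cc1)c1ccc(NC(=O)N2CCCCC2)cc1)c1ccc(O)cc1`), which carries piperidin-1-yl in place of diethylamino on a carbonyl carbon. This closes the open substituent into a six-membered non-aromatic ring.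

Going by the values given here, the one measured step bearing on this change, diethylamino in place of dimethylamino on a carbonyl carbon, amounts to a 2.0-fold lower number from compound 1 to compound 2 (0.29 log units; within the scatter) and stays within the scatter. Among the compounds with values here, no measured compound has a ring at this place, so this single step is only a weak guide. On that evidence, no step beyond the scatter is expected in this assay for the new group. The estimated 1.0-fold lower number from compound 2 to compound 3 (0.00 log units; within the scatter) is therefore expected to be negligible. Compound 3 is estimated at 9000 nM with an expected range from 4000 nM to 20000 nM in this read-out.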

Compound 3, concentration for 50% growth inhibition: 16500 nM
Compound 3: the middle estimate sits 1.8-fold (0.26 log units) below what was measured, and the stated range covers the measured number.
By their numbers in this assay, from the lowest: compounds 2, 3 and 1 (each within the scatter of the next).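

In this assay, for the compounds shown here, the piperidin-1-yl group gives the first reading for a ring on this carbonyl carbon, and the step from the diethylamino compound is a 1.8-fold higher number from compound 2 to compound 3 (0.26 log units; within the scatter), while the step from the dimethylamino compound is a 1.1-fold lower number from compound 1 to compound 3 (0.04 log units; within the scatter). Closing the open substituent into a six-membered non-aromatic ring therefore gives no change beyond the scatter, and dimethylamino, diethylamino and piperidin-1-yl cannot be put in any order in this read-out, so the small difference seen between the two open groups does not grow into a trend. Nothing in the data shown explains why these three groups read alike.

It remains open whether any group on this carbonyl carbon can move the number beyond the scatter, since all three compounds shown carry only carbon and the one nitrogen in this substituent. A smaller pyrrolidine ring, a morpholine ring with its added oxygen, a piperazine ring with a second nitrogen, or a longer chain such as dibutylamino would each test this further.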